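A few compounds are considered here, and "the series" means these few. Any claim that something is new, unique, unknown or untested is made for them only; others in the source may bear on it.

Measured compounds and their values in an assay on isolated protein for inhibition of Matrilysin (Homo sapiens), read by fluorescence, with a stated time of 15 min; on this read-out higher numbers stand for weaker inhibition and lower numbers for stronger inhibition:
- compound 1, `CSCC[C@H](NC(=O)[C@H](CC(C)C)NC(=O)[C@H](CC(N)=O)NC(=O)CC[C@H](NS(=O)(=O)c1ccc(Cl)c(C(F)(F)F)c1)C(=O)O)C(N)=O`, gives 7500 nM
- compound 2, `CSCC[C@H](NC(=O)[C@H](CC(C)C)NC(=O)CNC(=O)CC[C@H](NS(=O)(=O)c1ccc(Cl)c(C(F)(F)F)c1)C(=O)O)C(N)=O`, gives 120 nM
- compound 3, `CSCC[C@H](NC(=O)[C@H](CC(C)C)NC(=O)[C@H](C)NC(=O)CC[C@H](NS(=O)(=O)c1ccc(Cl)c(C(F)(F)F)c1)C(=O)O)C(N)=O`, gives 440 nM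

The three compounds share one core and differ only at a single saturated chain carbon. Compound 2 carries hydrogen there and has the lowest number of the three. Compound 3 differs from compound 2 by methyl in place of hydrogen on a saturated chain carbon bound to an amide-type nitrogen and a carbonyl carbon, a change that brought a 3.7-fold higher number from compound 2 to compound 3 (0.56 log units; beyond the scatter). Compound 1 differs from compound 2 by carbamoylmethyl in place of hydrogen on a saturated chain carbon bound to an amide-type nitrogen and a carbonyl carbon, and that change brought a 63-fold higher number from compound 2 to compound 1 (1.80 log units; beyond the scatter). Between compound 1 and compound 3 the difference reads as a 17-fold lower number from compound 1 to compound 3 (1.23 log units; beyond the scatter).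

Compound 4, `CSCC[C@H](NC(=O)[C@H](CC(C)C)NC(=O)[C@H](CCC(N)=O)NC(=O)CC[C@H](NS(=O)(=O)c1ccc(Cl)c(C(F)(F)F)c1)C(=O)O)C(N)=O`, is not yet measured. It differs from compound 3 by carbamoylmethyl in place of hydrogen on a saturated chain carbon, two bonds along the chain from an amide-type nitrogen and a carbonyl carbon. This is the same kind of change as that from compound 2 to compound 1, but not the same: there the carbamoylmethyl enters on a saturated chain carbon bound to an amide-type nitrogen and a carbonyl carbon, whereas here it enters on a saturated chain carbon two bonds along the chain from an amide-type nitrogen and a carbonyl carbon. Because a 63-fold higher number from compound 2 to compound 1 (1.80 log units; beyond the scatter) was a large loss, the same kind of addition is expected to raise the number for compound 4 as well, though with the group placed one carbon further out the step is estimated to be smaller, at a 5.7-fold higher number from compound 3 to compound 4 (0.75 log units; beyond the scatter). Compound 4 is therefore expected to give about 2500 nM, estimated within 700 nM to 9000 nM.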

Compound 4, half-maximal inhibitory concentration: 1300 nM
Compound 4: middle estimate off by 1.9-fold (0.28 log units), on the high side; the measured number falls inside the stated range.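

In this assay, the carbamoylmethyl addition raises the number on both cores, but its size does not carry over from one core to the other: the same change on two cores in this assay, a 63-fold higher number (1.80 log units; beyond the scatter) from compound 2 to compound 1 and a 3.0-fold higher number (0.47 log units; beyond the scatter) from compound 3 to compound 4, 21-fold (1.33 log units) apart, beyond the scatter of two such steps. On the core of compound 3 the step is a 3.0-fold higher number from compound 3 to compound 4 (0.47 log units; beyond the scatter), and compound 4 still sits well off the unsubstituted compound, with an 11-fold higher number from compound 2 to compound 4 (1.03 log units; beyond the scatter), while the 2-carbamoylethyl chain reads better than the carbamoylmethyl group of compound 1, with a 5.8-fold lower number from compound 1 to compound 4 (0.76 log units; beyond the scatter). This single pair shows that the direction of the change held and that its size cannot be transferred, but it does not show a rule for the series, and it cannot separate the effect of the starting core from that of the place where the group enters, since the two additions sit on different chain carbons.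

The compounds shown leave open how a carboxylic acid, an amine or a chain longer than 2-carbamoylethyl would read on the saturated chain carbon bound to an amide-type nitrogen and a carbonyl carbon. They also leave open whether the order seen among hydrogen, methyl, 2-carbamoylethyl and carbamoylmethyl would survive a change elsewhere in the shared core.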